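Replacing 3,4-dichlorophenyl with 4-methoxyphenyl in compound 2

A few compounds are considered here, and "the series" means these few. Any claim that something is new, unique, unknown or untested is made for them only; others in the source may bear on it.

- compound 1 `COc1ccc(/C=C/C(=O)NO)cc1OCC(=O)Nc1ccc(Br)cc1` gives 5390 nM
- compound 2 `COc1ccc(/C=C/C(=O)NO)cc1OCC(=O)Nc1ccc(Cl)c(Cl)c1` gives 13400 nM

In a functional assay on HeLa cells (Homo sapiens) for inhibition, read by MTT assay, with a stated time of 48 h (on this read-out lower numbers stand for stronger inhibition and higher numbers for weaker inhibition), compound 2 holds the higher of the two numbers (13400 nM), which makes it the weaker inhibitor. Compound 3 `COc1ccc(NC(=O)COc2cc(/C=C/C(=O)NO)ccc2OC)cc1` has not been measured yet. It carries 4-methoxyphenyl in place of 3,4-dichlorophenyl on an amide-type nitrogen and keeps the rest of compound 2 unchanged. For the measured compounds named here, only one measured step involves this same nitrogen: a 2.5-fold higher number from compound 1 to compound 2 (0.40 log units; beyond the scatter). Going by the values given here, that step was modest, and no measured compound yet carries 4-methoxyphenyl, so the guidance is thin. Compound 1 (5390 nM) shows that a different group here can give a lower number, so a modest step downward in this assay is expected, though its direction remains uncertain. The estimated change is a 1.7-fold lower number from compound 2 to compound 3 (0.22 log units; within the scatter). For compound 3 the expected value is 8000 nM, with an estimated range from 3000 nM to 20000 nM.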

Compound 3, half-maximal inhibitory concentration: 4870 nM
For compound 3 the middle estimate is 1.6-fold (0.22 log units) above the measured one; low and high end bracket the measured number.
By their numbers in this assay, from the lowest: compounds 3 and 1 (each within the scatter of the next); then compound 2.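

In this assay, putting 4-methoxyphenyl in place of 3,4-dichlorophenyl on the amide-type nitrogen gives a 2.8-fold lower number from compound 2 to compound 3 (0.44 log units; beyond the scatter), so the lower number seen earlier with 4-bromophenyl is not unique to that group. Methoxy in place of bromo on the aromatic carbon gives a 1.1-fold lower number from compound 1 to compound 3 (0.04 log units; within the scatter), so these two groups cannot be told apart here, and among the three compounds only the 3,4-dichlorophenyl group stands apart, with the higher number. No measurement at hand explains why.

Still open, from the compounds shown here alone, is whether plain phenyl or 4-chlorophenyl on this nitrogen reads like compound 3 or like compound 2. Also open, going by these compounds, is how a 4-aminophenyl group, or a phenyl ring carrying a carboxylic acid, reads in this assay.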